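A new group on the core of compound 2

A few compounds are considered here, and "the series" means these few. Any claim that something is new, unique, unknown or untested is made for them only; others in the source may bear on it.

Of the compounds shown here, three have numbers so far in a physicochemical assay for solubility, read by LC-MS, in phosphate buffer, with a stated time of 24 h, at pH 7.4 (a higher number here means a more soluble compound, a lower number a less soluble compound), and compound 2 (`Cc1ncc(-c2cnc(NCc3c(F)ccc4c3CCO4)c3cn[nH]c(=O)c23)n1C`) gives 15000 nM as the second highest of them. Compound 1 (`Cn1nccc1-c1cnc(NCc2c(F)ccc3c2CCO3)c2cn[nH]c(=O)c12`) shares its core and sits lower at 2000 nM on this scale, while compound 3 (`CN(c1ccn(C)n1)c1cnc(NCc2c(F)ccc3c2CCO3)n2cnnc12`) has a different core and sits higher at 130000 nM on the same scale.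

Compound 4 (`CN(c1ccn(C)n1)c1cnc(NCc2c(F)ccc3c2CCO3)c2cn[nH]c(=O)c12`) keeps the core of compound 2 and carries methyl(1-methyl-1H-pyrazol-3-yl)amino in place of 1,2-dimethyl-1H-imidazol-5-yl on an aromatic carbon. Within the data shown here, the one measured step at this place is a 7.5-fold higher number from compound 1 to compound 2 (0.88 log units; beyond the scatter) with 1,2-dimethyl-1H-imidazol-5-yl in place of 1-methyl-1H-pyrazol-5-yl. That step shows the number can move with the group here, but it does not involve the entering group. Among the measured compounds shown here, only compound 3 carries that group, with 130000 nM as its number, and no measured step separates the group from the core. The evidence is therefore thin, and it leans upward only through compound 3. The expected change is a 2.3-fold higher number from compound 2 to compound 4 (0.37 log units; beyond the scatter) and this estimate is uncertain. For compound 4 the estimated value is 35000 nM (expected range 8000 nM to 130000 nM).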

Compound 4, solubility: 12000 nM
Compound 4: the middle estimate sits 2.9-fold (0.46 log units) above what was measured, and the stated range covers the measured number.
By their numbers in this assay, from the lowest: compound 1; then compounds 4 and 2 (each within the scatter of the next); then compound 3.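

In this assay, methyl(1-methyl-1H-pyrazol-3-yl)amino in place of 1-methyl-1H-pyrazol-5-yl gives a 6.0-fold higher number from compound 1 to compound 4 (0.78 log units; beyond the scatter), while the same group in place of 1,2-dimethyl-1H-imidazol-5-yl gives a 1.3-fold lower number from compound 2 to compound 4 (0.10 log units; within the scatter), so on the shared core two quite different groups now cannot be told apart and compound 1 alone stands off from them. The entering group also turns out not to bring the number of compound 3 with it: compound 3 gives 130000 nM on its own core, whereas compound 4 gives 12000 nM with the same group on the core of compound 2. No measurement at hand explains either result, and the reason for these numbers remains unknown.

The compounds shown leave open whether a group without a ring on this aromatic carbon, such as dimethylamino, or one carrying a carboxylic acid, would stay level with compound 2 and compound 4 or move away from them. They also leave open how 1,2-dimethyl-1H-imidazol-5-yl would read on the core of compound 3, which would show whether that core keeps its number with another group.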